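A hydroxyphenyl variant of compound 1, awaiting its number

This account rests on a few compounds, and the source may have more. Where it says the series, first, only, none or still open, it means among the compounds named here.

Measured so far:
Compound 1, `COc1cc(Nc2nc(N[C@H]3CC[C@H](N)CC3)nc3c2ncn3CCC(C)C)cc(OC)c1`: 5900 nM
Compound 2, `CCCCn1cnc2c(Nc3cc(OC)cc(OC)c3)nc(N[C@H]3CC[C@H](N)CC3)nc21`: 15600 nM

In a functional assay on BT-474 cells (Homo sapiens) for inhibition, read by fluorescence, with a stated time of 72 h (on this read-out lower numbers stand for stronger inhibition of growth and higher numbers for weaker inhibition of growth), compound 1 gives 5900 nM, the lowest of the two numbers recorded. The nearest is compound 2, which in this assay gives 15600 nM. Among the compounds with values here, the one measured step, a 2.6-fold higher number from compound 1 to compound 2 (0.42 log units; beyond the scatter), arises from hydrogen in place of methyl on a saturated chain carbon bound to two saturated chain carbons, a part of the molecule that compound 3 leaves untouched.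

Compound 3, `CC(C)CCn1cnc2c(Nc3cccc(O)c3)nc(N[C@H]3CC[C@H](N)CC3)nc21`, differs from compound 1 in a different place: 3-hydroxyphenyl in place of 3,5-dimethoxyphenyl on a nitrogen on an aromatic ring. Within the data shown here, no measured step touches the group on that nitrogen, so the data give no direct guide and the expectation must stay wide. Compound 3 is estimated at 8000 nM, with a range from 2500 nM to 25000 nM. That estimate means an expected step of a 1.4-fold higher number from compound 1 to compound 3 (0.13 log units; within the scatter), which would not stand beyond the scatter.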

Compound 3, concentration for 50% growth inhibition: 14700 nM
The estimate for compound 3 lay 1.8-fold (0.26 log units) below the measured number, and the stated range covers the measured number.
By their numbers in this assay, from the lowest: compound 1; then compounds 3 and 2 (each within the scatter of the next).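

In this assay, within the data shown here, the group on a nitrogen on an aromatic ring proves able to shift the number, a position that no earlier step had touched: 3-hydroxyphenyl in place of 3,5-dimethoxyphenyl gives a 2.5-fold higher number from compound 1 to compound 3 (0.40 log units; beyond the scatter). The step is modest, yet it lies beyond the scatter, so compound 1 keeps the lowest number of the three compounds. Nothing measured here accounts for this step.

On these data alone, the change swaps the whole aryl group, so it remains open whether the rise in the number follows from the loss of a methoxy group or from the arrival of the hydroxyl; a 3-methoxyphenyl or 3,5-dihydroxyphenyl group on that nitrogen would help separate the two. As far as these compounds go, it is also open how a group such as an aminophenyl or a pyridyl would fare at this position.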